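A few compounds are considered here, and "the series" means these few. Any claim that something is new, unique, unknown or untested is made for them only; others in the source may bear on it.

Measured in a functional assay on NCI-H460 cells (Homo sapiens) for cytotoxicity, read by MTT assay, with a stated time of 72 h; a higher number here means a weaker inhibitor, a lower number a stronger inhibitor:
compound 1 `COc1cc2c(Oc3ccc(NC(=O)c4cn(-c5ccccc5Cl)nn4)cc3F)ccnc2cc1OCCCN1CCCC1` gives 190 nM
compound 2 `COc1cc2c(Oc3ccc(NC(=O)c4cn(-c5ccc(Br)cc5)nn4)cc3F)ccnc2cc1OCCCN1CCCC1` gives 200 nM
compound 3 `COc1cc2c(Oc3ccc(NC(=O)c4cn(-c5c(C)cccc5C)nn4)cc3F)ccnc2cc1OCCCN1CCCC1` gives 1560 nM

Compound 3 carries the highest number of the three: the steps of an 8.2-fold higher number from compound 1 to compound 3 (0.91 log units; beyond the scatter) and a 7.8-fold higher number from compound 2 to compound 3 (0.89 log units; beyond the scatter) both lie beyond the scatter. Compound 4 `COc1cc2c(Oc3ccc(NC(=O)c4cn(-c5c(C)cccc5C)nn4)cc3F)ccnc2cc1OCCCN1CCCCC1` differs from compound 3 by piperidin-1-yl in place of pyrrolidin-1-yl on a saturated chain carbon, three bonds along the chain from an oxygen on an aromatic ring. Neither measured step touches this part of the molecule; both concern the aryl group on the aromatic nitrogen, so they offer no guide to the change at hand. With nothing pointing either way, the step of a 1.0-fold lower number from compound 3 to compound 4 (0.02 log units; within the scatter) is expected to stay within the scatter. Compound 4 is therefore estimated at 1500 nM in this assay, with a range from 600 nM to 4000 nM.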

Compound 4, half-maximal inhibitory concentration: 3520 nM
Beside the measured number, compound 4's estimate is 2.3-fold (0.37 log units) below it, within the range that was stated.
By their numbers in this assay, from the lowest: compounds 1 and 2 (each within the scatter of the next); then compound 3; then compound 4.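

Among these compounds, the earlier compounds varied only the aryl group on the aromatic nitrogen, so this pair gives the first reading at the far end of the chain. In this assay, going from 3-(pyrrolidin-1-yl)propyl to 3-(piperidin-1-yl)propyl gives a 2.3-fold higher number from compound 3 to compound 4 (0.35 log units; beyond the scatter), showing that this ring is not a silent position when the 2,6-dimethylphenyl group is present. No supporting measurement is available to explain this step. From the compounds shown here alone, whether the change carries the same weight with 2-chlorophenyl or 4-bromophenyl remains open. So does the effect of a morpholine ring or a dimethylamine at this chain end.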